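The source may report more compounds than this note shows. Statements on the series, on what has been measured and on what is new or still open speak of the compounds shown alone.

Compound 1 `COc1ccc(-c2ncnn2-c2cc(OC)c(OC)c(OC)c2)cc1`: 520 nM
Compound 2 `COc1cc(-n2ncnc2-c2ccc(OC(F)(F)F)cc2)cc(OC)c1OC`: > 10000 nM, a limit of the assay
Compound 3 `CCOc1ccc(-c2ncnn2-c2cc(OC)c(OC)c(OC)c2)cc1`: 100 nM

In a functional assay on A549 cells (Homo sapiens) for antiproliferative activity, read by MTT assay, with a stated time of 72 h (on this read-out lower numbers stand for stronger inhibition and higher numbers for weaker inhibition), compound 3 stands lowest of the three, at 100 nM. Methyl in place of hydrogen on the chain carbon bound to the oxygen gave a 5.2-fold lower number from compound 1 to compound 3 (0.72 log units; beyond the scatter), a modest step and the closest precedent. Changes at the same oxygen can be far larger: trifluoromethyl in place of methyl gave an at least 19-fold higher number from compound 1 to compound 2 (1.28 log units; beyond the scatter), and ethyl in place of trifluoromethyl gave an at least 100-fold lower number from compound 2 to compound 3 (2.00 log units; beyond the scatter). Compound 4 `COc1cc(-n2ncnc2-c2ccc(OC(C)C)cc2)cc(OC)c1OC` differs by methyl in place of hydrogen on a saturated chain carbon bound to an oxygen on an aromatic ring and a saturated chain carbon, which turns ethoxy into isopropoxy. With a single modest precedent and large swings nearby, only a small upward step is expected, though with wide uncertainty. The expected step is a 2.0-fold higher number from compound 3 to compound 4 (0.30 log units; within the scatter). Compound 4 is estimated at 200 nM, within an expected range of 40 nM to 1500 nM.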

Compound 4, half-maximal inhibitory concentration: > 10000 nM
Compound 4: only a limit was reported; the forecaster's own chance of this, stated with the estimate: 7%; middle value at least 50-fold (1.69 log units) from the limit.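

In this assay, among these compounds, this position proves far less forgiving than the earlier compounds suggested: one more methyl, turning ethoxy into isopropoxy, gave an at least 100-fold higher number from compound 3 to compound 4 (2.00 log units; beyond the scatter), reversing the direction of the earlier added methyl, which gave a 5.2-fold lower number from compound 1 to compound 3 (0.72 log units; beyond the scatter). Isopropoxy also fell behind methoxy, with an at least 19-fold higher number from compound 1 to compound 4 (1.28 log units; beyond the scatter). The step between compound 2 and compound 4 cannot be read, since both values are limits: the limit of > 10000 nM in this assay, at which 2 of the 4 values shown sit. The compounds shown leave open whether an unbranched propoxy chain would keep the low number of ethoxy, and how a cyclopropylmethoxy group would fare.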